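The compounds below may be only part of what the source reports. "The series", "measured", "known", "first", "only" and "open" are said of these compounds alone.

Series notes. In an in vitro functional assay on cells for agonist activity at Bombesin receptor subtype-3 (Mus musculus), read by luminescence and calcium flux (on this read-out higher numbers stand for an effect only at larger amounts of compound and lower numbers for an effect already at smaller amounts), compound 1 `CCCCc1cnc(C(C)Cc2ccc(-c3ccccc3C(=O)O)cc2)[nH]1` gives 184 nM and compound 2 `CCCCc1cnc(CCCc2ccc(-c3ccccc3C(=O)O)cc2)[nH]1` gives 382 nM. Compound 3 `Cc1cccc(Cc2cnc(CCc3ccc(-c4ccccc4C(=O)O)cc3)[nH]2)c1` gives 75 nM in this assay, the lowest of the three numbers; its gaps to compound 1 and to compound 2 both lie beyond the scatter. Compound 4 `CC(C)(C)CCc1cnc(CCc2ccc(-c3ccccc3C(=O)O)cc2)[nH]1` is not yet measured. The change from compound 3 to compound 4: neopentyl in place of 3-methylphenyl on a saturated chain carbon bound to an aromatic carbon. For the measured compounds named here, no single step between measured compounds isolates a chain replacing a ring; compound 1 with 184 nM and compound 2 with 382 nM carry a chain and give higher numbers than compound 3, yet each also differs from compound 3 elsewhere. A moderate rise is expected, a 2.0-fold higher number from compound 3 to compound 4 (0.30 log units; within the scatter) in this assay. Compound 4 is estimated at 150 nM, within 50 nM to 450 nM.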

Compound 4, half-maximal effective concentration: 6.2 nM
Compound 4: the middle estimate sits 24-fold (1.38 log units) above what was measured, outside the stated range (below it).
By their numbers in this assay, from the lowest: compound 4; then compound 3; then compound 1; then compound 2.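

At the place on a saturated chain carbon bound to an aromatic carbon, the aromatic ring is not required for a low number in this assay: neopentyl in place of 3-methylphenyl gives a 12-fold lower number from compound 3 to compound 4 (1.08 log units; beyond the scatter). For the compounds shown here, this is the first single step that isolates a chain replacing a ring, and here the chain carries the lower number. Nothing at hand explains the size of this step. On these data alone, it remains open whether the step follows from losing the aromatic ring or from the branched chain end; a cyclohexyl or a straight pentyl group at this place would separate the two.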